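Amino for dimethylamino in a chloro compound

The source may report more compounds than this note shows. Statements on the series, on what has been measured and on what is new or still open speak of the compounds shown alone.

In an ADME assay on CCRF-CEM cells (Homo sapiens) for cytotoxicity, with a stated time of 5 days (a higher number here means a weaker inhibitor, a lower number a stronger inhibitor), compound 1 `CC(C)(CO)Nc1nc(N)nc2c1ncn2[C@H]1C[C@H](N=[N+]=[N-])[C@@H](CO)O1` gives > 100000 nM, which is a limit and not a number. Compound 2 `CN(C)c1nc(N)nc2c1ncn2[C@H]1C[C@H](N=[N+]=[N-])[C@@H](CO)O1` gives > 100000 nM, again a limit. Compound 3 `CN(C)c1nc(Cl)nc2c1ncn2[C@H]1C[C@H](N=[N+]=[N-])[C@@H](CO)O1` gives > 100000 nM, also only a limit. All three compounds therefore share one position: the limit of > 100000 nM in this assay, at which 3 of the 3 values shown sit. None of them offers a number to build on.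

Compound 4 `[N-]=[N+]=N[C@H]1C[C@H](n2cnc3c(N)nc(Cl)nc32)O[C@@H]1CO` has not yet been measured. It differs from compound 3 by a single change, amino in place of dimethylamino on an aromatic carbon.

Within the data shown here, two measured steps bear on this change. The closer is a step that the two limits leave unreadable from compound 1 to compound 2, where dimethylamino also enters. The other is a step that the two limits leave unreadable from compound 2 to compound 3, which brings in the chloro group that compound 4 keeps. Neither gives a size that could be carried over.

With only limits behind it, the estimate assumes no large move, and the one direction in which a move could be seen is toward a stronger inhibitor. The expected change is small: an at least 1.2-fold lower number from compound 3 to compound 4 (0.09 log units; that floor lies within the scatter). For compound 4 the estimated value in this assay is 80000 nM, with an expected range from 20000 nM to 120000 nM, and a reading at the limit again is the likeliest result.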

Compound 4, half-maximal inhibitory concentration: > 100000 nM
Compound 4 was reported as a limit (the forecaster's own chance of this, stated with the estimate: 65%); middle value at least 1.2-fold (0.09 log units) from the limit.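

In this assay compound 4 gives > 100000 nM, which is a limit and not a number. No size can be read for the change from compound 3 to compound 4, as both compounds hold the same position: the limit of > 100000 nM in this assay, at which 4 of the 4 values shown sit. The compounds shown leave open whether any change on the shared core would give a readable number in this assay.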